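A 4-fluorobenzyl group added to compound 1

The source may hold more compounds than are shown below. What is called first, only, known or untested is meant among the compounds shown, and "the series" means these compounds.

Results in a functional assay on Bel7402/5-FU cells (Homo sapiens) for antiproliferative activity, read by MTT assay, with a stated time of 72 h (a higher number here means a weaker inhibitor, a lower number a stronger inhibitor), for the three measured compounds
Compound 1 `C=C1C(=O)O[C@H]2[C@H]1CC/C(COC(=O)Cn1cc(F)c(=O)[nH]c1=O)=C\CC[C@@]1(C)O[C@@H]21` gives > 20000 nM
Compound 2 `C=C1C(=O)O[C@H]2[C@H]1CC/C(COC(=O)CCC(=O)OCn1cc(F)c(=O)[nH]c1=O)=C\CC[C@@]1(C)O[C@@H]21` gives > 20000 nM
Compound 3 `C=C1C(=O)O[C@H]2[C@H]1CC/C(COC(=O)CCC(=O)N1CCN(C(=O)Cn3cc(F)c(=O)[nH]c3=O)CC1)=C\CC[C@@]1(C)O[C@@H]21` gives > 20000 nM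

Compound 1 stands at > 20000 nM as a limit of the assay and not as a number. The three compounds together show the limit of > 20000 nM in this assay, at which 3 of the 3 values shown sit, and so none of them has an exact potency. They give no ranking, and compound 1 has no measured value from which a new compound can be counted.

Compound 4 `C=C1C(=O)O[C@H]2[C@H]1CC/C(COC(=O)Cn1cc(F)c(=O)n(Cc3ccc(F)cc3)c1=O)=C\CC[C@@]1(C)O[C@@H]21` keeps the shared core and makes one change. Compared with compound 1, it carries 4-fluorobenzyl in place of hydrogen on an aromatic nitrogen and is otherwise the same.

Among the compounds with values here, no measured pair shows what such a change does in this assay so the size of the step is a judgement. A modest move toward stronger inhibition is expected, though compound 4 could well remain at the limit of the assay. The expected size is an at least 1.6-fold lower number from compound 1 to compound 4 (0.22 log units; that floor lies within the scatter) as an estimate only. For compound 4 the estimated value is 12000 nM with an expected range from 4000 nM to 30000 nM in this estimate.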

Compound 4, half-maximal inhibitory concentration: 1140 nM
For compound 4 the middle estimate is 11-fold (1.02 log units) above the measured one, and the stated range ends above it.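

In this assay, putting 4-fluorobenzyl in place of hydrogen on the aromatic nitrogen gives an at least 17-fold lower number from compound 1 to compound 4 (1.24 log units; beyond the scatter). This is the first change shown that brings a compound into the measurable range, so this nitrogen is a position where a substituent can alter the read-out, something the earlier compounds could not reveal: the limit of > 20000 nM in this assay, at which 3 of the 4 values shown sit. The step is only a floor: compound 1 gives > 20000 nM, which is a limit of the assay and not a number, so the true size of the change may be larger.

With a single group at this position, the compounds shown cannot separate the contribution of the benzyl ring from that of its fluoro group, or show whether simply replacing the hydrogen is enough; a plain benzyl, a methyl or a 4-methoxybenzyl group on the same nitrogen would bear on both questions. Going by these compounds, it also remains open whether the same 4-fluorobenzyl group would bring compound 2 or compound 3, with their longer linking chains, into the measurable range.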